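From a Limit to a Number: Adding 3-Fluorobenzyl

This account rests on a few compounds, and the source may have more. Where it says the series, first, only, none or still open, it means among the compounds named here.

In a functional assay on Bel7402/5-FU cells (Homo sapiens) for antiproliferative activity, read by MTT assay, with a stated time of 72 h (a higher number here means a weaker inhibitor, a lower number a stronger inhibitor), compound 1 `C=C1C(=O)O[C@H]2[C@H]1CC/C(COC(=O)Cn1cc(F)c(=O)[nH]c1=O)=C\CC[C@@]1(C)O[C@@H]21` gives > 20000 nM, which is a limit of the assay and not a number. Compound 2 `C=C1C(=O)O[C@H]2[C@H]1CC/C(Cn1cc(Cn3cc(F)c(=O)n(Cc4ccc(F)cc4)c3=O)nn1)=C\CC[C@@]1(C)O[C@@H]21`, which also carries a fluorobenzyl group, gives 4860 nM in this assay, although its link to the shared core differs as well. Compound 3 `C=C1C(=O)O[C@H]2[C@H]1CC/C(COC(=O)Cn1cc(F)c(=O)n(Cc3cccc(F)c3)c1=O)=C\CC[C@@]1(C)O[C@@H]21` keeps the ester link of compound 1 and changes one place: 3-fluorobenzyl stands in place of hydrogen on an aromatic nitrogen (3-fluorobenzyl in place of hydrogen on an aromatic nitrogen). Going by compound 2 with its 4860 nM, a gain in strength beyond the usual scatter is expected in this assay, which would show as a lower number. The expected move is an at least 3.0-fold lower number from compound 1 to compound 3 (0.48 log units; beyond the scatter). For compound 3 the estimated value is 6500 nM, with an expected range from 2000 nM to 18000 nM.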

Compound 3, half-maximal inhibitory concentration: 3700 nM
The estimate for compound 3 lay 1.8-fold (0.24 log units) above the measured number; measured number inside the range.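

On the ester link, the aromatic nitrogen of compound 1 can carry 3-fluorobenzyl in place of hydrogen with a real gain in strength, and in this assay this single change gives an at least 5.4-fold lower number from compound 1 to compound 3 (0.73 log units; beyond the scatter). Going by these compounds alone, compound 2 could not show this, as its link to the shared core differs as well, so compound 3 is the first clean reading of this position. On these data alone, compound 1 stands only at a limit of the assay, not at a number, so the full size of the step stays unknown: the limit of > 20000 nM in this assay, at which 1 of the 3 values shown sits.

The compounds shown cannot separate the benzyl ring from its fluoro group, nor say how much the place of the fluoro group on that ring matters. A plain benzyl group, or a longer chain ending in an amine, on this nitrogen would test how much of the gain depends on 3-fluorobenzyl itself.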